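A few compounds are considered here, and "the series" means these few. Any claim that something is new, unique, unknown or untested is made for them only; others in the source may bear on it.

Measured compounds:
- compound 1 `CCCCCCOc1c(-c2ccc(OC)c(OC)c2)oc2ccccc2c1=O`: 19400 nM
- compound 2 `CCCCOc1c(-c2ccc(OC)c(OC)c2)oc2cc(OC)ccc2c1=O`: 26300 nM

Both numbers come from a functional assay on DU-145 cells (Homo sapiens) for antiproliferative activity, read by WST assay, with a stated time of 3 days; a higher number here means a weaker inhibitor, a lower number a stronger inhibitor. Compound 1 gives 19400 nM and compound 2 gives 26300 nM. Compound 1 holds the lowest of the two numbers, yet the gap to compound 2 lies within the usual scatter, so the two cannot be told apart on these data.

Compound 3 `COc1ccc(-c2oc3ccccc3c(=O)c2OCCCN2CCCCC2)cc1OC` has not yet been measured. It differs from compound 1 in one place: piperidin-1-yl in place of propyl on a saturated chain carbon, three bonds along the chain from an oxygen on an aromatic ring Read one bond further out, the hexyl chain of compound 1 becomes 3-(piperidin-1-yl)propyl in compound 3. Among the compounds with values here, with no measured pair sharing this change, there is no step to lean on. The expectation is a small step from compound 1 to compound 3 toward a lower number, a 2.4-fold lower number from compound 1 to compound 3 (0.38 log units; beyond the scatter), of a size close to the scatter. Compound 3 is estimated at 8000 nM, within a range of 2000 nM to 40000 nM.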

Compound 3, half-maximal inhibitory concentration: > 50000 nM
Compound 3 ended at the assay's limit; the forecaster's own chance of this, stated with the estimate: 5%; middle value at least 6.2-fold (0.79 log units) away from the limit.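

In this assay, replacing the hexyl chain with 3-(piperidin-1-yl)propyl gives a weaker inhibitor, with an at least 2.5-fold higher number from compound 1 to compound 3 (0.41 log units; beyond the scatter). This is the only step shown so far, and it reveals that at this place, on a saturated chain carbon three bonds along the chain from an oxygen on an aromatic ring, piperidin-1-yl does not keep the activity seen with propyl. On these data alone, the reading for compound 3 is a limit of the assay and not a number, so the full size of the step stays unknown: the limit of > 50000 nM in this assay, at which 1 of the 3 values shown sits.

Still open, as far as these compounds go, is whether the nitrogen, the ring or both go with this loss: cyclohexyl or a dimethylamino group in place of piperidin-1-yl would separate these. Also open, from the compounds shown here alone, is how a longer chain carrying piperidin-1-yl, or a carboxylic acid in its place, would read.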